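This account rests on a few compounds, and the source may have more. Where it says the series, first, only, none or still open, it means among the compounds named here.

Compound 1 `Cc1cc(C(=O)Nc2ccccc2)nn1Cc1cc(Cl)ccc1OCc1ccccc1` belongs to this series, but in an in vivo ADME assay on the whole organism (blood) for pharmacokinetics, with Rattus norvegicus as the target (a higher number here means faster removal of the compound, a lower number slower removal), compound 1 gives "not determined" (no result reported), so no number is available for it. Compound 2 `Cc1cc(NC(=O)c2ccccc2)nn1Cc1cc(Cl)ccc1OCc1ccccc1` gives 50 mL/min/kg in this assay, and compound 3 `Cc1cc(NC(=O)C2CCCCC2)nn1Cc1cc(Cl)ccc1OCC(C)C` gives 68 mL/min/kg; these two numbers sit within the usual scatter of each other, so neither can be called faster or slower cleared than the other. Among the measured compounds shown here, no pair of measured compounds differs in just one place, so no single structural step has a known effect on clearance here.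

Compound 4 `Cc1cc(NC(=O)O[C@H]2CCOC2)nn1Cc1cc(Cl)ccc1OCc1ccccc1` is the next compound to be measured. It differs from compound 2 in one place: (oxolan-3-yl)oxy in place of phenyl on a carbonyl carbon. Because compound 2 gives 50 mL/min/kg and nothing in the measured pairs shows that such a change moves clearance beyond the scatter, the step from compound 2 to compound 4 is expected to be small, in either direction or none at all, with the estimate a 1.1-fold lower number from compound 2 to compound 4 (0.05 log units; within the scatter). Compound 4 is therefore expected to give about 45 mL/min/kg, within a range from 22 mL/min/kg to 90 mL/min/kg.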

Compound 4, clearance: 86 mL/min/kg
Compound 4: the middle estimate sits 1.9-fold (0.28 log units) below what was measured; the range from low to high includes it.
By their numbers in this assay, from the lowest: compounds 2, 3 and 4 (each within the scatter of the next).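

In this assay, among the compounds shown here, the first single-place step reads a 1.7-fold higher number from compound 2 to compound 4 (0.24 log units; within the scatter), which lies within the usual scatter. At this carbonyl carbon, whose other neighbour is an amide-type nitrogen, the six-membered aromatic phenyl ring gives way to (oxolan-3-yl)oxy, with its five-membered non-aromatic ring, two hydrogen-bond acceptors and one defined stereocentre, and the heavy-atom count stays the same; even so, the two clearance numbers cannot be told apart. No accompanying measurement bears on this result.

Going by these compounds, whether a different group on the same carbonyl carbon, such as a dimethylamino group or a longer alkyl chain, would give a step beyond the scatter remains open. So does whether the opposite stereoisomer of the (oxolan-3-yl)oxy group would give a similar clearance.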